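This account rests on a few compounds, and the source may have more. Where it says the series, first, only, none or still open, it means among the compounds named here.

Measured compounds:
compound 1, `CC(=O)OC[C@H]1O[C@@H](n2cc(-c3cn(Cc4ccc(C(C)C)cc4)nn3)c(=O)[nH]c2=O)C[C@@H]1OC(C)=O`, 95.4%
compound 2, `CC(C)(C)c1ccc(-c2cc(-c3cn([C@H]4C[C@H](O)[C@@H](CO)O4)c(=O)[nH]c3=O)on2)cc1`, 88%

Of the compounds shown here, two have been measured in a functional assay on NUGC-3 cells (Homo sapiens) for cytotoxicity, read by sulforhodamine B assay, tested at 10 uM; a lower number here means less inhibition, a higher number more inhibition at the concentration tested (going by the name of the read-out). Compound 1 gives 95.4%, and compound 2 gives 88%; the two numbers lie within the usual scatter of each other, so neither compound can be set above the other on this evidence. Compound 1 is the starting point for the step considered here.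

Compound 3, `CC(=O)OC[C@H]1O[C@@H](n2cc(-c3cn(Cc4ccccc4)nn3)c(=O)[nH]c2=O)C[C@@H]1OC(C)=O`, has not yet been measured in this assay. It differs from compound 1 in one place: hydrogen in place of isopropyl on an aromatic carbon. Within the data shown here, no step between two measured compounds of this kind is available, so the size of the effect must be guessed. In this assay the change is expected to lower inhibition, and the expected step is a number 20.4 percentage points lower from compound 1 to compound 3 (beyond the scatter), a drop that is estimated to lie beyond the scatter, though with wide uncertainty. Compound 3 is therefore estimated at 75% in this assay, within the range 40% to 97%.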

Compound 3, a percentage reported as inhibition, at one concentration (the size of the read-out at that concentration, not a potency): 88.7%
For compound 3 the middle estimate is 13.7 percentage points below the measured one; low and high end bracket the measured number.
By their numbers in this assay, from the lowest: compounds 2, 3 and 1 (each within the scatter of the next).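

Among these compounds, exchanging isopropyl for hydrogen on the aromatic carbon, which turns 4-isopropylbenzyl into benzyl, gives in this assay a number 6.7 percentage points lower from compound 1 to compound 3 (within the scatter) and so provides the first direct comparison at this position. The isopropyl group is therefore not required for compound 3 to read alike with compound 1 at the concentration tested, and the plain benzyl form stays within the scatter of the substituted one. No measurement at hand offers an explanation for this result.

From the compounds shown here alone, whether a different group at this place, such as an amine, a carboxylic acid or a longer alkyl chain, would also leave the number within the scatter remains open. Going by these compounds, the read-out comes from one concentration and is not a potency, so how compound 1 and compound 3 compare in potency also stays open.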